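The source may hold more compounds than are shown below. What is called first, only, known or untested is meant among the compounds shown, and "the series" means these compounds.

Working notes on the series, read in a functional assay on HUVEC cells (Homo sapiens) for inhibition, with stated times of 2 h and 72 h; on this read-out higher numbers stand for weaker inhibition and lower numbers for stronger inhibition. Compound 1 (`COc1cc2nccc(Oc3ccc4c(NC(=O)Nc5ccc(C(F)(F)F)cc5Cl)nn(C)c4c3)c2cc1OC`) gives > 1000 nM, which is a limit. Compound 2 (`COc1cc2nccc(Oc3ccc4c(NC(=O)c5cc(Cl)ccn5)nn(C)c4c3)c2cc1OC`) gives > 1000 nM, also a limit and not a number, so its standing is known only as the limit of > 1000 nM in this assay, at which 2 of the 2 values shown sit. For the measured compounds named here, the single measured step is a step that the two limits leave unreadable from compound 1 to compound 2, and it offers no size to carry forward. Compound 3 (`COc1ccc(C(=O)Nc2nn(C)c3cc(Oc4ccnc5cc(OC)c(OC)cc45)ccc23)cc1`) has 4-methoxyphenyl in place of 4-chloropyridin-2-yl on a carbonyl carbon. With no readable size behind it, the expected step in this assay is a step that the limit leaves unreadable from compound 2 to compound 3, with no direction claimed beyond the scatter. For compound 3 the estimated value is 2500 nM, with an expected range of 800 nM to 10000 nM.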

Compound 3, half-maximal inhibitory concentration: > 1000 nM
Compound 3 was reported as a limit (the forecaster's own chance of this, stated with the estimate: 75%); the middle value lies beyond the limit too.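

The steps among compound 1, compound 2 and compound 3 cannot be read, because all three stand at the same limit: the limit of > 1000 nM in this assay, at which 3 of the 3 values shown sit. The compounds shown leave open how far these groups on the carbonyl carbon differ in inhibition.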